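Series notes: amide hydrolase inhibition, compounds 2 to 3

This account rests on a few compounds, and the source may have more. Where it says the series, first, only, none or still open, it means among the compounds named here.

Measured so far in an assay on HEK293 cells for inhibition of Fatty-acid amide hydrolase 1 (Homo sapiens), read by fluorescence; on this read-out higher numbers stand for weaker inhibition and lower numbers for stronger inhibition:
- compound 1, `Cn1ccc2cc(-c3ccc4oc(Cc5ccccc5)nc4c3)ccc21`, gives 488 nM
- compound 2, `CN(c1ccccc1)c1nc2cc(-c3ccc4c(ccn4C)c3)ccc2o1`, gives 68 nM

Among the compounds with values here, compound 2 stands at the lowest of the two numbers in this assay; the nearest value is that of compound 1, and the only step in hand, a 7.2-fold lower number from compound 1 to compound 2 (0.86 log units; beyond the scatter), lies beyond the scatter.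

Compound 3, `Cn1ccc2cc(-c3ccc4oc(Nc5ccc(F)cc5)nc4c3)ccc21`, differs from compound 2 in one place: (4-fluorophenyl)amino in place of methyl(phenyl)amino on an aromatic carbon. The substituent that leaves and the one that enters are both aryl-bearing amino groups attached at the same carbon of the shared core, each with one hydrogen-bond acceptor, while the entering group carries one hydrogen-bond donor and a fluorine that the leaving group does not.

Within the data shown here, no measured step swaps one arylamino group for another. The step of a 7.2-fold lower number from compound 1 to compound 2 (0.86 log units; beyond the scatter) concerns a different exchange, benzyl to methyl(phenyl)amino, and shows only that this position tolerates an arylamino group. From it no direction for compound 3 can be read. The expectation for compound 3 is therefore a step of a 1.2-fold higher number from compound 2 to compound 3 (0.07 log units; within the scatter), within the scatter, with compound 3 estimated at 80 nM in this assay, ranging from 25 nM to 260 nM.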

Compound 3, half-maximal inhibitory concentration: 99 nM
For compound 3 the middle estimate is 1.2-fold (0.09 log units) below the measured one; the measured number falls inside the stated range.
By their numbers in this assay, from the lowest: compounds 2 and 3 (each within the scatter of the next); then compound 1.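

In this assay, the exchange gives a 1.5-fold higher number from compound 2 to compound 3 (0.16 log units; within the scatter), so this read-out does not separate these two arylamino groups, although only the entering group carries a hydrogen-bond donor and a fluorine. Set against benzyl on the same aromatic carbon, (4-fluorophenyl)amino gives a 4.9-fold lower number from compound 1 to compound 3 (0.69 log units; beyond the scatter), and the lower number seen with compound 2 is thus no longer tied to methyl(phenyl)amino alone: both amino-linked groups shown stand beyond the scatter from the benzyl group of compound 1. Nothing at hand accounts for either step.

The exchange from compound 2 to compound 3 removes the methyl on the linking nitrogen and adds the fluorine at once, and the compounds shown do not separate these two changes; plain phenylamino and methyl(4-fluorophenyl)amino on this carbon would do so. Also open, on these data alone, is whether an aromatic ring on this nitrogen is needed at all, a question that a dimethylamino or morpholine group at the same place would address.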